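The source may hold more compounds than are shown below. What is called first, only, known or untested is meant among the compounds shown, and "the series" means these compounds.

Measured so far in a functional assay on HCT-116 cells (Homo sapiens) for cytotoxicity, read by MTT assay, with a stated time of 72 h; on this read-out lower numbers stand for stronger inhibition and higher numbers for weaker inhibition:
Compound 1 `O=C(NCc1ccc(F)cc1)c1nc(Br)c2cccnc2c1NCCCNc1c(C(=O)NCc2ccc(F)cc2)nc(Br)c2cccnc12` — a limit of the assay, > 20000 nM.
Compound 2 `C[C@@H](Nc1c(C(=O)NCc2ccc(F)cc2)nc(Br)c2cccnc12)c1ccccc1` — a limit of the assay, > 20000 nM.
Compound 3 `C[C@H](NC(=O)c1nc(Br)c2cccnc2c1N[C@H]1CC[C@H](N)CC1)c1ccc(F)cc1` — a limit of the assay, > 10000 nM.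

Compound 2 thus stands where every measured compound on this core stands: at a limit, with no number behind it. Two of the three values sit at the limit of > 20000 nM in this assay, at which 2 of the 3 values shown sit, and one at the limit of > 10000 nM in this assay, at which 1 of the 3 values shown sits. Compound 4 `O=C(NCc1ccc(F)cc1)c1nc(Br)c2cccnc2c1N1CCNCC1` differs from compound 2 in one place: piperazin-1-yl in place of (1-phenylethyl)amino on an aromatic carbon. Going by the values given here, no measured step between compounds on this core exists, so no size of change can be read from the data; the step expected in this assay is none beyond the scatter. Compound 4 is therefore expected to give 25000 nM, within 8000 nM to 80000 nM, most probably again reported only as a limit. That expectation means a step that the limit leaves unreadable from compound 2 to compound 4.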

Compound 4, half-maximal inhibitory concentration: > 10000 nM
Compound 4: a limit, no number; the forecaster's own chance of this, stated with the estimate: 80%; the middle value is on the limit's open side.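

Going by these compounds alone, compound 2 and compound 4 both stand only at limits in this assay, so no step between them can be read. The compounds shown leave open whether any group on the shared core gives a measurable value.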